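A few compounds are considered here, and "the series" means these few. Any claim that something is new, unique, unknown or untested is made for them only; others in the source may bear on it.

Measured compounds in an ADME assay on MIA PaCa-2 cells (Homo sapiens) for cytotoxicity, read by MTT assay, with a stated time of 72 h; a higher number here means a weaker inhibitor, a lower number a stronger inhibitor:

compound 1, `COc1ccc(C2=C(c3cc(OC)c(OC)c(OC)c3)C(=O)C(OC(C)=O)C2)cc1F`: 39.5 ug/mL
compound 2, `COC(=O)c1cc(C2=C(c3cc(OC)c(OC)c(OC)c3)C(=O)CC2O[SiH2]C(C)(C)C)ccc1OC`: > 100 ug/mL
compound 3, `COc1ccc(C2=C(c3cc(OC)c(OC)c(OC)c3)C(=O)C(O)C2)cc1NC(=O)c1ccccc1`: > 100 ug/mL

Compound 3 stands at a limit of this assay, not at a number. Compound 2 also returns only a limit in this assay. Among the three values shown, two sit at the limit of > 100 ug/mL in this assay, at which 2 of the 3 values shown sit, and compound 1 is the only one with a number, giving 39.5 ug/mL in this assay.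

The next compound, compound 4, `COc1ccc(C2=C(c3cc(OC)c(OC)c(OC)c3)C(=O)C(O)C2)cc1`, is the analogue of compound 3 with hydrogen in place of benzamido on an aromatic carbon. It carries a hydroxyl on the shared core like compound 3 and is closer to compound 1 than compound 3 is, differing from compound 1 only in the fluoro and in the acetoxy against hydroxyl.

Compound 3 stands at a limit, so the step to compound 4 cannot be measured against a number. The expectation is a move toward a lower number in this assay, of a size beyond the usual scatter, because compound 1 gives 39.5 ug/mL. Compound 4 is expected at 45 ug/mL, within 15 ug/mL to 100 ug/mL, which would mean an estimated step of an at least 2.2-fold lower number from compound 3 to compound 4 (0.34 log units; beyond the scatter).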

Compound 4, half-maximal inhibitory concentration: < 1 ug/mL
Compound 4: a limit, no number; the forecaster's own chance of this, stated with the estimate: 35%; at least 45-fold (1.65 log units) between middle value and limit.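

In this assay compound 4 gives < 1 ug/mL, a limit and not a number. Compound 3 also stands at a limit, > 100 ug/mL. Hydrogen in place of benzamido on this aromatic carbon, ortho to a methoxy group, gives an at least 100-fold lower number from compound 3 to compound 4 (2.00 log units; beyond the scatter), so this single position spans both ends of the range shown and is far more sensitive to change than the earlier compounds could show.

As far as these compounds go, how far past its limit compound 4 lies stays open: the limit of < 1 ug/mL in this assay, at which 1 of the 4 values shown sits. Whether a smaller group on the same aromatic carbon, such as an amine or an acetamido group, keeps the number low, or whether only hydrogen does, cannot be told from these compounds.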